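Substituents on the phenyl of the shared core

The source may report more compounds than this note shows. Statements on the series, on what has been measured and on what is new or still open speak of the compounds shown alone.

Compound 1 `COc1cc2ncnc(Nc3cc(-c4ccccc4)[nH]n3)c2cc1OC` carries an unsubstituted phenyl on the shared core. In a functional assay on BT-20 cells (Homo sapiens) for cytotoxicity, read by MTT assay (a higher number here means a weaker inhibitor, a lower number a stronger inhibitor), compound 1 gives only a limit, < 100000 nM, and not a number. Compound 2 `COc1cc2ncnc(Nc3cc(-c4ccc(F)cc4)[nH]n3)c2cc1OC` is recorded in this assay at a limit of < 100000 nM. Compound 3 `COc1cc2ncnc(Nc3cc(-c4ccc(Cl)cc4)[nH]n3)c2cc1OC` likewise shows a limit of < 100000 nM in this assay. All three therefore sit at the same boundary, (the limit of < 100000 nM in this assay, at which 3 of the 3 values shown sit), and none of the comparisons among them yields a readable size: a step that the two limits leave unreadable from compound 1 to compound 2, a step that the two limits leave unreadable from compound 1 to compound 3 and a step that the two limits leave unreadable from compound 2 to compound 3.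

Compound 4 `COc1ccc(-c2cc(Nc3ncnc4cc(OC)c(OC)cc34)n[nH]2)cc1` is the next member, differing from compound 1 by methoxy in place of hydrogen on an aromatic carbon. Within the data shown here, the steps that bear on this change are the two from compound 1 to its substituted analogues, and both are unreadable, so neither a direction nor a size can be taken from them for this assay. The only inference available is that every variation tried on this phenyl so far has left the value at the limit, and the expectation is that compound 4 will behave the same way. The estimated step that the limit leaves unreadable from compound 1 to compound 4 is accordingly expected to remain unreadable. For compound 4 the estimate in this assay is 60000 nM, within 10000 nM to 200000 nM, with a limit the most probable outcome.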

Compound 4, half-maximal inhibitory concentration: < 100000 nM
Compound 4: no number, only a limit (the forecaster's own chance of this, stated with the estimate: 75%); the middle value lies beyond the limit too.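

In this assay compound 4 gives < 100000 nM, a limit and not a number. Its steps from compound 1, compound 2 and compound 3 therefore cannot be read, and the series stays at one boundary: the limit of < 100000 nM in this assay, at which 4 of the 4 values shown sit.

The compounds shown leave open whether any of these phenyl substituents changes the value, in which direction and by how much.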